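Replacing dimethoxyphenyl with carboxyphenyl on a limit-bound compound

A few compounds are considered here, and "the series" means these few. Any claim that something is new, unique, unknown or untested is made for them only; others in the source may bear on it.

Compound 3 `C=C1[C@@H](OC(C)=O)C[C@@H]2[C@](C)(COC=O)[C@H](OC(C)=O)CC[C@@]2(C)[C@@H]1C[C@@H](Nc1ccc(OC)c(OC)c1)C1=CCOC1=O` carries a 3,4-dimethoxyphenyl group on its amine nitrogen. In a functional assay on A549 cells (Homo sapiens) for cytotoxicity, read by sulforhodamine B assay (a lower number here means a stronger inhibitor, a higher number a weaker inhibitor), compound 3 gives only a limit of the assay, > 50000 nM, so no number is known for it. Two related compounds did give numbers: compound 1 `C=C1[C@@H](OC(C)=O)C[C@@H]2[C@](C)(CO[Si](C)(C)C(C)(C)C)[C@H](OC(C)=O)CC[C@@]2(C)[C@@H]1C[C@@H](Nc1ccccc1F)C1=CCOC1=O` gives 3190 nM in this assay, and compound 2 `C=C1[C@@H](OC(C)=O)C[C@@H]2[C@](C)(CO[Si](C)(C)C(C)(C)C)[C@H](OC(C)=O)CC[C@@]2(C)[C@@H]1C[C@@H](Nc1ccc(OC)cc1)C1=CCOC1=O` gives 4810 nM in this assay; both, however, also differ from compound 3 at the side chain of the core, so their values are only a backdrop. For the measured compounds named here, the one measured step, a 1.5-fold higher number from compound 1 to compound 2 (0.18 log units; within the scatter), shows that swapping one aryl group for another on the amine nitrogen left the number within the scatter. Compound 4 `C=C1[C@@H](OC(C)=O)C[C@@H]2[C@](C)(COC=O)[C@H](OC(C)=O)CC[C@@]2(C)[C@@H]1C[C@@H](Nc1ccc(C(=O)O)cc1)C1=CCOC1=O` differs from compound 3 in one place: 4-carboxyphenyl in place of 3,4-dimethoxyphenyl on an amine nitrogen. Going by the values given here, no measured step covers the entry of a carboxyphenyl group, and the starting point is itself a limit (the limit of > 50000 nM in this assay, at which 1 of the 3 values shown sits), so the expected step of a number no higher from compound 3 to compound 4 (the limit leaves the size open) rests on little beyond compound 3 itself. Compound 4 is therefore expected to give about 50000 nM in this assay, between 10000 nM and 200000 nM, most likely again only a limit.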

Compound 4, half-maximal inhibitory concentration: > 50000 nM
Compound 4 was reported as a limit (the forecaster's own chance of this, stated with the estimate: 65%); the middle value lies on the limit itself.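

Compound 3 and compound 4 both stand only as limits in this assay, so no step between them can be read: the limit of > 50000 nM in this assay, at which 2 of the 4 values shown sit.

Still open, from the compounds shown here alone, is the true number of each compound, and whether 4-carboxyphenyl in place of 3,4-dimethoxyphenyl on the amine nitrogen changes it at all.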